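Ethoxy in place of ethoxycarbonyl on the chain

This account rests on a few compounds, and the source may have more. Where it says the series, first, only, none or still open, it means among the compounds named here.

Values in an ADME assay on L929 cells (Mus musculus) for cytotoxicity, read by resazurin assay, with a stated time of 48 h; on this read-out higher numbers stand for lower toxicity in this test and lower numbers for higher toxicity in this test:
- compound 1 `COC(=O)Cn1c2ccc([N+](=O)[O-])cc2c(=O)n1Cc1ccccc1`: 129000 nM
- compound 2 `CCOC(=O)CCCn1c2ccc([N+](=O)[O-])cc2c(=O)n1Cc1ccccc1`: 78100 nM
- compound 3 `O=c1c2cc([N+](=O)[O-])ccc2n(CCCO)n1Cc1ccccc1`: > 256000 nM

The entry for compound 3, > 256000 nM, is a limit of the assay. The low end of the numbers is shared: a 1.7-fold lower number from compound 1 to compound 2 (0.22 log units; within the scatter).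

Compound 4 `CCOCCCn1c2ccc([N+](=O)[O-])cc2c(=O)n1Cc1ccccc1` carries ethoxy in place of ethoxycarbonyl on a saturated chain carbon, three bonds along the chain from an aromatic nitrogen. Going by the values given here, no measured compound carries ethoxy. Among the compounds with values here, the one measured change at this place, to hydroxy, gave an at least 3.2-fold higher number from compound 2 to compound 3 (0.51 log units; beyond the scatter), so a smaller shift in the same direction is expected in this assay, probably not beyond the scatter. The expected step is a 1.5-fold higher number from compound 2 to compound 4 (0.19 log units; within the scatter). For compound 4 the estimated value is 120000 nM, with an expected range from 60000 nM to 240000 nM.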

Compound 4, concentration lethal to 50% of the cells: 170000 nM
The estimate for compound 4 lay 1.4-fold (0.15 log units) below the measured number, within the range that was stated.
By their numbers in this assay, from the lowest: compounds 2, 1 and 4 (each within the scatter of the next, the first and the last beyond it). At a limit, above all of these: compound 3.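

In this assay, this place now has a step of measured size rather than only a floor: a 2.2-fold higher number from compound 2 to compound 4 (0.34 log units; beyond the scatter), so a step beyond the scatter here does not need a free hydroxy. The step from the methoxycarbonyl compound stays within the scatter: a 1.3-fold higher number from compound 1 to compound 4 (0.12 log units; within the scatter). The entry for compound 3 is a limit, so ethyl on its oxygen reads only as a floor: an at least 1.5-fold lower number from compound 3 to compound 4 (0.17 log units; that floor lies within the scatter).

As far as these compounds go, whether hydroxy and ethoxy truly differ at this place stays open. So does how a carboxylic acid or an amine on this chain would read in this assay.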